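The source may hold more compounds than are shown below. What is called first, only, known or untested is meant among the compounds shown, and "the series" means these compounds.

Working notes on the series. Compound 1 `CC(C)(C)c1cn(CCNc2nonc2/C(=N/O)Nc2ccc(F)c(Br)c2)nn1` carries tert-butyl on an aromatic carbon of the five-membered aromatic ring with 3 nitrogen; in an assay on isolated protein for inhibition of Indoleamine 2,3-dioxygenase 1 (Homo sapiens) (a lower number here means a stronger inhibitor, a higher number a weaker inhibitor), compound 1 gives 132 nM. Compound 2 `OCCc1cn(CCNc2nonc2/C(=N/O)Nc2ccc(F)c(Br)c2)nn1` has 2-hydroxyethyl in that place and gives 247 nM in this assay, the step being a 1.9-fold higher number from compound 1 to compound 2 (0.27 log units; within the scatter). Compound 3 `CC(C)(O)c1cn(CCNc2nonc2/C(=N/O)Nc2ccc(F)c(Br)c2)nn1` carries 1-hydroxy-1-methylethyl and gives 115 nM in this assay; the step of a 1.1-fold lower number from compound 1 to compound 3 (0.06 log units; within the scatter), and the step of a 2.1-fold lower number from compound 2 to compound 3 (0.33 log units; beyond the scatter). Compound 3 thus has the lowest of the three numbers, but its gap to compound 1 is within the scatter, so the two cannot be ordered; only its gap to compound 2 is beyond the scatter, and modestly so.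

Compound 4 `O/N=C(\Nc1ccc(F)c(Br)c1)c1nonc1NCCn1cc(C2(O)CCCCC2)nn1` differs from compound 3 in one place: 1-hydroxycyclohexyl in place of 1-hydroxy-1-methylethyl on an aromatic carbon. The hydroxy stays on the saturated carbon bound to the aromatic carbon, and the change replaces the two methyl groups by a six-membered non-aromatic ring of carbon only. For the measured compounds named here, no measured step probes such a ring; the steps that bear on the same position, a 1.1-fold lower number from compound 1 to compound 3 (0.06 log units; within the scatter) and a 1.9-fold higher number from compound 1 to compound 2 (0.27 log units; within the scatter), were small, and even the largest, a 2.1-fold lower number from compound 2 to compound 3 (0.33 log units; beyond the scatter), was modest. Going by the values given here, every change at this position so far has moved this assay little, so for compound 4 the expected step is a 1.0-fold higher number from compound 3 to compound 4 (0.02 log units; within the scatter), no shift beyond the scatter in either direction. Compound 4 is therefore estimated at 120 nM in this assay, with a range of 50 nM to 300 nM.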

Compound 4, half-maximal inhibitory concentration: 62 nM
The estimate for compound 4 lay 1.9-fold (0.29 log units) above the measured number; the measured number falls inside the stated range.
By their numbers in this assay, from the lowest: compounds 4, 3, 1 and 2 (each within the scatter of the next, the first and the last beyond it).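

The six-membered non-aromatic ring of carbon only is accepted at this position in this assay: with 1-hydroxycyclohexyl in place of 1-hydroxy-1-methylethyl the result is a 1.9-fold lower number from compound 3 to compound 4 (0.27 log units; within the scatter), so the two groups cannot be ordered. Unlike compound 3, however, compound 4 stands clear of the tert-butyl compound, with a 2.1-fold lower number from compound 1 to compound 4 (0.33 log units; beyond the scatter), and the widest gap at this position so far is a 4.0-fold lower number from compound 2 to compound 4 (0.60 log units; beyond the scatter), though both of these remain modest. No measurement at hand accounts for any of these steps.

The compounds shown leave open how much of the number depends on the hydroxy and how much on the ring, since each ring-free hydroxy group here differs from 1-hydroxycyclohexyl in more than the ring alone, and a plain cyclohexyl group would separate the two. Also open, going by these compounds, is how far the ring can vary, for instance as 1-hydroxycyclopentyl, or with an amine in the ring as in 4-hydroxypiperidin-4-yl, or with a carboxylic acid in place of the hydroxy.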